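A few compounds are considered here, and "the series" means these few. Any claim that something is new, unique, unknown or untested is made for them only; others in the source may bear on it.

Two measured compounds share one core, and they differ only in the group that hangs from the aminomethyl arm. Compound 1 `CN1[C@@H]2c3[nH]c4ccccc4c3C[C@H]1[C@H](C#N)N1[C@@H](CN3C(=O)c4ccccc4C3=O)c3[nH]c4ccccc4c3C[C@@H]21` carries a phthalimide there, and in a functional assay on HCT-116 cells (Homo sapiens) for cytotoxicity, read by MTT assay, with a stated time of 72 h (a lower number here means a stronger inhibitor, a higher number a weaker inhibitor), compound 1 gives 40 nM. Compound 2 `CN1[C@@H]2c3[nH]c4ccccc4c3C[C@H]1[C@H](C#N)N1[C@@H](CNC(=O)c3cccc4c3CCCC4)c3[nH]c4ccccc4c3C[C@@H]21` carries an amide of a tetrahydronaphthalene acid instead, and in this assay compound 2 gives 4210 nM, the higher of the two numbers and a gap from compound 1 that lies beyond the usual scatter. Compound 3 `CN1[C@@H]2c3[nH]c4ccccc4c3C[C@H]1[C@H](C#N)N1[C@@H](CNC(=O)c3cc4ccccc4o3)c3[nH]c4ccccc4c3C[C@@H]21` keeps the amide link of compound 2 and changes only the acid part: 1-benzofuran-2-yl in place of 1,2,3,4-tetrahydronaphthalen-5-yl on a carbonyl carbon. For the measured compounds named here, with no measured pair that mirrors this exchange, the expected step from compound 2 to compound 3 is small, a 1.4-fold lower number from compound 2 to compound 3 (0.15 log units; within the scatter), and is not expected to reach beyond the scatter. On that basis compound 3 is estimated at 3000 nM, with a likely range from 600 nM to 15000 nM.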

Compound 3, half-maximal inhibitory concentration: 330 nM
The estimate for compound 3 lay 9.1-fold (0.96 log units) above the measured number; the whole stated range lies above it.
By their numbers in this assay, from the lowest: compound 1; then compound 3; then compound 2.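

In this assay the acid part of the amide proves to be a sensitive place: 1-benzofuran-2-yl in place of 1,2,3,4-tetrahydronaphthalen-5-yl gives a 13-fold lower number from compound 2 to compound 3 (1.11 log units; beyond the scatter) and lies beyond the scatter, so an amide link on this arm does not by itself set a high number. The phthalimide still holds the lowest number of the three, with an 8.3-fold higher number from compound 1 to compound 3 (0.92 log units; beyond the scatter), which means that compound 3 closes only part of the gap that separated compound 2 from compound 1. No measurement shown here bears on why the 1-benzofuran-2-yl amide reads lower.

Still open, on these data alone, is whether the ring oxygen counts or the five-membered aromatic ring itself, and a benzothiophene, with sulfur in that place, could separate the two. Also open, as far as these compounds go, is how an amide carrying a plain phenyl ring or an open alkyl chain would read.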